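Sorbamide to bromocrotonamide on a trimethoxyanilide core

The source may report more compounds than this note shows. Statements on the series, on what has been measured and on what is new or still open speak of the compounds shown alone.

Compound 1 `C/C=C/C(=O)N(Cc1cccc(O)c1)c1cc(OC)c(OC)c(OC)c1`: 14700 nM
Compound 2 `C/C=C/C=C/C(=O)N(Cc1ccc(OC)c(O)c1)c1cc(OC)c(OC)c(OC)c1`: 180 nM
Compound 3 `COc1cc(NCc2ccccc2)cc(OC)c1OC`: > 80000 nM

Of the compounds shown here, three share the trimethoxyphenyl nitrogen core and have been measured in a functional assay on KYSE-450 cells (Homo sapiens) for inhibition, read by MTT assay, with a stated time of 48 h; a lower number here means a stronger inhibitor, a higher number a weaker inhibitor. Compound 2 gives 180 nM and stands at the lowest of the two numbers recorded. Its nearest neighbour, compound 1, gives 14700 nM, a gap well beyond the scatter. Compound 3, which carries no acyl group at all, reaches only the assay limit (the limit of > 80000 nM in this assay, at which 1 of the 3 values shown sits); its result is a limit, not a number. No pair of these compounds differs in a single place, so no measured step can be drawn between them.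

Compound 4 `COc1ccc(CN(C(=O)/C=C/CBr)c2cc(OC)c(OC)c(OC)c2)cc1O` has not yet been measured. Relative to compound 2 it differs in one place: bromomethyl in place of prop-1-en-1-yl on a double-bonded chain carbon bound to a double-bonded chain carbon. The acyl chain of compound 2 is thus shortened and the terminal alkenyl arm is exchanged for a bromomethyl group, while the benzyl ring and the core are unchanged.

Among the measured compounds shown here, with no measured step of this kind to lean on, the size of the expected change is uncertain; compound 4 is estimated at 300 nM, within a range of 40 nM to 3000 nM, which means an expected step from compound 2 of a 1.7-fold higher number from compound 2 to compound 4 (0.22 log units; within the scatter) that may or may not exceed the scatter.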

Compound 4, half-maximal inhibitory concentration: 100 nM
Beside the measured number, compound 4's estimate is 3.0-fold (0.48 log units) above it, within the range that was stated.
By their numbers in this assay, from the lowest: compounds 4 and 2 (each within the scatter of the next); then compound 1. At a limit, above all of these: compound 3.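

In this assay, putting bromomethyl in place of prop-1-en-1-yl on a double-bonded chain carbon bound to a double-bonded chain carbon gives a 1.8-fold lower number from compound 2 to compound 4 (0.26 log units; within the scatter), so the two compounds read alike. This is the only step among the compounds shown that changes a single place, and it shows that at this position the penta-1,3-dien-1-yl arm can give way to 3-bromoprop-1-en-1-yl, a different end to the chain, without a change beyond the scatter. Nothing measured here explains why these two acyl groups read alike.

Open, on these data alone, is how other groups would read in this place, such as chloromethyl, an aminomethyl group or a longer chain, and a plain methyl on the same benzyl ring would show whether the bromine itself counts for anything. Also open, as far as these compounds go, is whether the same exchange would read alike with a different substitution on the benzyl ring, since this single step holds that ring fixed.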